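Removing the pendant methyl of compound 1

The compounds below may be only part of what the source reports. "The series", "measured", "known", "first", "only" and "open" are said of these compounds alone.

Compound 1 `Cc1ccc([C@@H]2CC(=O)c3ccc(C)cc3O2)cc1` gives 590 nM in an in vitro assay on BTI-TN-5B1-4 cells for inhibition of Amine oxidase [flavin-containing] B (Homo sapiens) (a higher number here means a weaker inhibitor, a lower number a stronger inhibitor), the highest of the three numbers. Compound 2 `Cc1ccc(C2CC(=O)c3ccc(C)cc3O2)cc1` gives 500 nM; the step of a 1.2-fold lower number from compound 1 to compound 2 (0.07 log units; within the scatter) is within the scatter, the pair differing only in that (the fact that one of compounds 1 and 2 is drawn with a defined configuration and the other without, at the place where they differ). Compound 3 `Cc1ccc([C@@H]2CC(=O)c3ccc(F)cc3O2)cc1` gives 150 nM, and the step of a 3.9-fold lower number from compound 1 to compound 3 (0.59 log units; beyond the scatter) is the only one beyond the scatter. Compound 4 `Cc1ccc2c(c1)O[C@H](c1ccccc1)CC2=O` differs from compound 1 by hydrogen in place of methyl on an aromatic carbon, on the six-membered aromatic ring of carbon only, para to a large group. Neither measured step bears directly on this change: the change behind a 3.9-fold lower number from compound 1 to compound 3 (0.59 log units; beyond the scatter) sits on the other ring, and a 1.2-fold lower number from compound 1 to compound 2 (0.07 log units; within the scatter) is a stereochemical difference only, so in this assay no step beyond the scatter is expected. Compound 4 is estimated at 600 nM, range 250 nM to 1500 nM, an expected step of a 1.0-fold higher number from compound 1 to compound 4 (0.01 log units; within the scatter).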

Compound 4, half-maximal inhibitory concentration: 110 nM
For compound 4 the middle estimate is 5.5-fold (0.74 log units) above the measured one; the measured number lies below the stated range.
By their numbers in this assay, from the lowest: compounds 4 and 3 (each within the scatter of the next); then compounds 2 and 1 (each within the scatter of the next).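

In this assay, hydrogen in place of methyl on an aromatic carbon, para to a large group, gives a 5.4-fold lower number from compound 1 to compound 4 (0.73 log units; beyond the scatter), a step beyond the scatter. Within the data shown here, this position therefore affects the read-out, which the earlier steps could not show, since they concerned a stereo element and a change on the other ring. Nothing at hand explains why removing this methyl gives a lower number.

From the compounds shown here alone, whether an amine, a methoxy group or a longer chain at this position would be tolerated remains open. So does whether the same step would appear with fluoro on the other ring.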